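Ketone to carbinol on the heptanoic acid side of compound 1

The source may hold more compounds than are shown below. What is called first, only, known or untested is meant among the compounds shown, and "the series" means these compounds.

Of the compounds shown here, two have been measured so far: compound 1 `CCCCCC(=O)c1ccc(CN(CCCCCCC(=O)O)S(C)(=O)=O)cc1` and compound 2 `CCCCc1ccc(CN(c2ccccc2CCCC(=O)O)S(C)(=O)=O)cc1`. In an assay on HEK293 cells for inhibition of prostaglandin E2 receptor EP4 subtype (Rattus norvegicus) (on this read-out lower numbers stand for stronger inhibition and higher numbers for weaker inhibition), compound 1 gives > 3200 nM, which is a limit of the assay and not a number. In this assay compound 2 gives > 3200 nM, again a limit rather than a number. Compound 1 therefore stands at the weak end of what has been seen, and the two measured compounds cannot be ordered against each other; what is shown is the limit of > 3200 nM in this assay, at which 2 of the 2 values shown sit.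

Compound 3 `CCCCC(O)c1ccc(CN(CCCCCCC(=O)O)S(C)(=O)=O)cc1` is the next member and differs from compound 1 by 1-hydroxypentyl in place of pentylcarbonyl on an aromatic carbon. Going by the values given here, because the limit of > 3200 nM in this assay, at which 2 of the 2 values shown sit, leaves no measured step, the size of any change cannot be read from the data, and no direction is indicated. In this assay compound 3 is expected to behave much like compound 1, with a step that the limit leaves unreadable from compound 1 to compound 3 that is expected to be none beyond the scatter. Compound 3 is estimated at 6000 nM, with a range from 2000 nM to 20000 nM, most likely reported again only as a limit.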

Compound 3, half-maximal inhibitory concentration: > 3200 nM
Compound 3: a limit, no number (the forecaster's own chance of this, stated with the estimate: 75%); the middle value is on the limit's open side.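

In this assay compound 3 gives > 3200 nM, a limit of the assay and not a number. Going by these compounds alone, no step from compound 1 to compound 3 can be read, because every value sits at the same limit: the limit of > 3200 nM in this assay, at which 3 of the 3 values shown sit. The compounds shown leave open how 1-hydroxypentyl and pentylcarbonyl rank against each other, and which change to the core of compound 1 would give a measured number.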